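Swapping the carboxyphenyl amide for a carboxypyridyl amide

A few compounds are considered here, and "the series" means these few. Any claim that something is new, unique, unknown or untested is made for them only; others in the source may bear on it.

Measured so far:
compound 1, `COc1ccc(-c2nc3cc(F)c(F)cc3n2[C@H](C(=O)N[C@H]2CC[C@H](C(=O)O)CC2)C2CCCCC2)c(Cl)n1`, 290 nM
compound 2, `O=C(O)c1cccc(NC(=O)C(C2CCCCC2)n2c(-c3ccc(Cl)cc3)nc3cc(F)c(F)cc32)c1`, 1300 nM
compound 3, `COc1cc(C(=O)O)ccc1NC(=O)[C@H](C1CCCCC1)n1c(-c2ccc(Cl)cc2)nc2cc(F)c(F)cc21`, 740 nM

All three were tested in an assay on isolated protein for displacement of a labelled ligand from Bile acid receptor (Homo sapiens), read by scintillation proximity assay and radioligand binding; on this read-out higher numbers stand for weaker inhibition and lower numbers for stronger inhibition. Compound 2 stands at the highest of the three numbers. Its nearest neighbour is compound 3, whose value sits within the scatter of that of compound 2, so no order between the two can be read. Compound 1 lies further off, beyond the scatter, with the lower number.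

Compound 4, `O=C(O)c1ccc(NC(=O)C(C2CCCCC2)n2c(-c3ccc(Cl)cc3)nc3cc(F)c(F)cc32)nc1`, has not yet been measured. It differs from compound 2 in one place: 5-carboxypyridin-2-yl in place of 3-carboxyphenyl on an amide-type nitrogen. For the measured compounds named here, no measured pair shows this exact change, so the expected size of the step rests on the spread of the three known values. Compound 4 is expected to land close to compound 2, with any shift most likely toward a somewhat lower number, and the estimated step of a 1.6-fold lower number from compound 2 to compound 4 (0.21 log units; within the scatter) may well stay within the scatter. Compound 4 is estimated at 800 nM, within a range from 300 nM to 2500 nM.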

Compound 4, half-maximal inhibitory concentration: 200 nM
Beside the measured number, compound 4's estimate is 4.0-fold (0.60 log units) above it; measured number outside the range, below it.
By their numbers in this assay, from the lowest: compounds 4 and 1 (each within the scatter of the next); then compounds 3 and 2 (each within the scatter of the next).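

In this assay, for the compounds shown here, placing 5-carboxypyridin-2-yl instead of 3-carboxyphenyl on the amide-type nitrogen gives a 6.5-fold lower number from compound 2 to compound 4 (0.81 log units; beyond the scatter), the first step here that can be read from a pair differing in one place, and it shows that the number responds to this group. The swap keeps the heavy-atom count and adds one hydrogen-bond acceptor, but it changes the ring and the numbering of the carboxy group together. Nothing at hand explains the lower number.

The compounds shown leave open whether the ring nitrogen or the placement of the carboxy group accounts for the step, which 4-carboxyphenyl on the same nitrogen would help separate. They also leave open whether the carboxylic acid itself is needed, as a primary carboxamide or a tetrazole in its place on the pyridine ring would show.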